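A few compounds are considered here, and "the series" means these few. Any claim that something is new, unique, unknown or untested is made for them only; others in the source may bear on it.

Compound 1 `CCSCCC12CCC(c3nnc(-c4ccccc4C(F)(F)F)n3C)(CC1)CC2` carries an (ethylsulfanyl)methyl chain on its core. In an assay on CHO-K1 cells for inhibition of 11-beta-hydroxysteroid dehydrogenase type 2 (Mus musculus), read by scintillation proximity assay (on this read-out lower numbers stand for stronger inhibition and higher numbers for weaker inhibition), compound 1 gives > 4000 nM, which is a limit of the assay and not a measured number. A second compound, compound 2 `Cn1c(-c2ccccc2C(F)(F)F)nnc1C12CCC(COc3ccc(S(C)(=O)=O)cc3)(CC1)CC2`, differs from compound 1 in one place: 4-(methylsulfonyl)phenoxy in place of (ethylsulfanyl)methyl on a saturated chain carbon bound to a saturated ring carbon. Compound 2 gives > 4000 nM in this assay, again a limit. The step between them is a step that the two limits leave unreadable from compound 1 to compound 2, so its size cannot be read. Going by the values given here, the only evidence available is the limit of > 4000 nM in this assay, at which 2 of the 2 values shown sit.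

Compound 3 `CCS(=O)(=O)CCCCC12CCC(c3nnc(-c4ccccc4C(F)(F)F)n3C)(CC1)CC2` is the one not yet measured. It differs from compound 1 thus: 2-(ethylsulfonyl)ethyl in place of ethylsulfanyl on a saturated chain carbon, two bonds along the chain from a saturated ring carbon. Among the compounds with values here, no measured step bears on this change: the single comparison from compound 1 leaves no readable size. With both measured values at the limit, the most likely outcome is that compound 3 also reports only a limit in this assay. The expected step is a step that the limit leaves unreadable from compound 1 to compound 3. Compound 3 is therefore estimated at 8000 nM, in a range from 2000 nM to 40000 nM.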

Compound 3, half-maximal inhibitory concentration: > 4000 nM
Compound 3 gave a limit, no number (the forecaster's own chance of this, stated with the estimate: 80%); the middle value does not contradict the limit.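

With compound 3 also giving only a limit, none of the steps among compound 1, compound 2 and compound 3 can be read in this assay: the limit of > 4000 nM in this assay, at which 3 of the 3 values shown sit.

The compounds shown leave open how strongly each one inhibits the enzyme, and whether changing the chain on the shared core alters that inhibition at all.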